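From Hydroxy to Ethoxy on the Shared Core

The source may hold more compounds than are shown below. What is called first, only, known or untested is meant among the compounds shown, and "the series" means these compounds.

In a functional assay (trachea) with Cavia porcellus as the target (on this read-out lower numbers stand for an effect already at smaller amounts and higher numbers for an effect only at larger amounts of compound), compound 1 `CCCn1c(=O)n(C)c(=O)c2c1ncn2CC(N)=O` gives > 100000 nM, which is a limit and not a number. Compound 2 `CCCn1c(=O)n(C)c(=O)c2c1ncn2CCCN(C)C` gives > 100000 nM, which is likewise a limit. Among the compounds with values here, compound 3 `CCCn1c(=O)n(C)c(=O)c2c1ncn2CCO` gives 31800 nM, the only actual number, and it is the lowest reading so far. The remaining evidence is the limit of > 100000 nM in this assay, at which 2 of the 3 values shown sit.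

Compound 4 `CCCn1c(=O)n(C)c(=O)c2c1ncn2CCOCC` keeps the shared core and differs from compound 3 in one place: ethyl in place of hydrogen on an oxygen on a saturated carbon. In short, 2-hydroxyethyl becomes 2-ethoxyethyl.

Within the data shown here, two measured steps bear on this change, an at least 3.1-fold lower number from compound 1 to compound 3 (0.49 log units; beyond the scatter) and an at least 3.1-fold lower number from compound 2 to compound 3 (0.49 log units; beyond the scatter). Both run towards the hydroxy group, which leans any departure from it towards a higher number. Each gives only a minimum size, and neither replaces the hydrogen on the oxygen, so the evidence for this change is indirect. The expected change is a 1.2-fold higher number from compound 3 to compound 4 (0.08 log units; within the scatter), with no step beyond the scatter anticipated. Compound 4 is expected at 38000 nM, with an estimated range from 12000 nM to 100000 nM.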

Compound 4, half-maximal effective concentration: 4600 nM
Compound 4: the middle estimate sits 8.3-fold (0.92 log units) above what was measured; measured number below the stated range.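

Ethyl in place of hydrogen on this oxygen is not a neutral change in this assay: 2-hydroxyethyl to 2-ethoxyethyl gives a 6.9-fold lower number from compound 3 to compound 4 (0.84 log units; beyond the scatter), the first step in the series with an actual number at both ends. Within the data shown here, the earlier compounds showed only that the hydroxy compound reads lower than those with the carbamoyl or dimethylamino chain ends, and compound 4 adds that the hydrogen on this oxygen is not required for the effect, since the number falls once it is replaced. Compound 4 now has the lowest reading of the series, with an at least 21-fold lower number from compound 2 to compound 4 (1.33 log units; beyond the scatter) and an at least 21-fold lower number from compound 1 to compound 4 (1.33 log units; beyond the scatter), and both are minimum sizes only because compound 1 and compound 2 each rest on a limit: the limit of > 100000 nM in this assay, at which 2 of the 4 values shown sit.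

Going by these compounds, only hydrogen and ethyl stand on this oxygen, and it stays open whether methyl, a butyl chain or benzyl there would take the number further down or bring it back up. Also open, on these data alone, is whether a 3-ethoxypropyl chain would hold the reading of 2-ethoxyethyl.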